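Methyl on a Saturated Ring Carbon: Two Different Cores

The compounds below may be only part of what the source reports. "The series", "measured", "known", "first", "only" and "open" are said of these compounds alone.

Measured compounds:
Compound 1, `O=C(O)CCC/C=C1\CC2C[C@@H](O)[C@H](/C=C/[C@@H](O)C3COc4ccccc4O3)C2C1`, 0.0045 mg/kg
Compound 2, `CC1([C@H](O)/C=C/[C@@H]2C3C/C(=C/CCCC(=O)O)CC3C[C@H]2O)COc2ccccc2O1`, 0.0142 mg/kg
Compound 3, `O=C(O)COC/C=C1\CC2C[C@@H](O)[C@H](/C=C/[C@@H](O)C3Cc4ccccc4C3)C2C1`, 0.0675 mg/kg

Of the compounds shown here, three have been measured in a functional assay on the whole organism (stomach) for inhibition, with Rattus norvegicus as the target; on this read-out lower numbers stand for an effect already at smaller amounts and higher numbers for an effect only at larger amounts of compound. Compound 1 gives 0.0045 mg/kg, compound 2 gives 0.0142 mg/kg, and compound 3 gives 0.0675 mg/kg, the highest number of the three.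

Compound 2 differs from compound 1 in a single place: methyl in place of hydrogen on a saturated ring carbon. This change gave a 3.2-fold higher number from compound 1 to compound 2 (0.50 log units; beyond the scatter).

Compound 3 rests on a different core from compound 1, and the difference between the two cores is not broken down here. Compound 3 carries a hydrogen at the position where compound 4, `CC1([C@H](O)/C=C/[C@@H]2C3C/C(=C/COCC(=O)O)CC3C[C@H]2O)Cc2ccccc2C1`, carries a methyl: methyl in place of hydrogen on a saturated ring carbon. This is the same kind of change as that from compound 1 to compound 2, but not the same change, since in compound 2 the methyl sits on a saturated ring carbon of a six-membered non-aromatic ring with two oxygen, next to the ring oxygen and two ring bonds from the ring oxygen, whereas in compound 4 it sits on a saturated ring carbon of a five-membered non-aromatic ring of carbon only.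

For compound 4 the expected step in this assay is a 3.0-fold higher number from compound 3 to compound 4 (0.47 log units; beyond the scatter), resting on the measured step from compound 1 to compound 2, a 3.2-fold higher number from compound 1 to compound 2 (0.50 log units; beyond the scatter); the surroundings of the place differ between the two cores, and extra width is allowed for that. Compound 4 is thus estimated at 0.2 mg/kg, in a range from 0.07 mg/kg to 0.6 mg/kg.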

Compound 4, dose for half-maximal effect: 0.0397 mg/kg
Estimate against measurement, compound 4: 5.0-fold (0.70 log units) above, outside the stated range (below it).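

In this assay the methyl on a saturated ring carbon of a five-membered non-aromatic ring of carbon only gives a 1.7-fold lower number from compound 3 to compound 4 (0.23 log units; within the scatter) and so has no effect on this core that can be told from the scatter. The same kind of change therefore did not carry over in size from one core to the other, and the step measured on the first core would have been a poor guide to the second: the same change on two cores in this assay, a 3.2-fold higher number (0.50 log units; beyond the scatter) from compound 1 to compound 2 and a 1.7-fold lower number (0.23 log units; within the scatter) from compound 3 to compound 4, 5.4-fold (0.73 log units) apart, beyond the scatter of two such steps. This does not show why the two steps part, for the methyl sits in a different ring in each pair and the two cores differ in other places as well, and two pairs cannot separate these differences or say which result a further core would follow.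

The compounds shown leave open whether a group other than methyl on the same saturated ring carbon, such as ethyl or a hydroxyl group, would also differ between the two cores. They also leave open how the methyl would behave if only the ring carrying it were exchanged while the rest of the molecule stayed the same.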